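Trading 1H-benzimidazol-2-yl for 1,3-benzothiazol-2-yl

The compounds below may be only part of what the source reports. "The series", "measured", "known", "first", "only" and "open" are said of these compounds alone.

Of the compounds shown here, three sharing one core have been measured so far in an ADME assay on microsomes from liver (Mus musculus) for metabolic stability, read by LC-MS, with a stated time of 10 min, tested at 0.5 uM (a higher number here means that more of the compound is left, a lower number that less of the compound is left), and they give a first picture. Compound 1 `c1ccc2c(c1)CN[C@H](CN(CCCN1CCNCC1)[C@H]1CCCc3cccnc31)C2` stands at 88% while compound 2 `c1cnc2c(c1)CCC[C@@H]2N(CCCN1CCNCC1)Cc1cc2ccccc2cn1` stands at 74% and compound 3 `c1cnc2c(c1)CCC[C@@H]2N(CCCN1CCNCC1)Cc1nc2ccccc2[nH]1` stands at 68% remaining. Compound 3 therefore sits clearly under compound 1 and level, within the scatter, with compound 2.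

Compound 4 `c1cnc2c(c1)CCC[C@@H]2N(CCCN1CCNCC1)Cc1nc2ccccc2s1` differs from compound 3 in one place only: it carries 1,3-benzothiazol-2-yl in place of 1H-benzimidazol-2-yl on a saturated chain carbon bound to an amine nitrogen and the rest stays the same.

The nearest guide is the exchange of isoquinolin-3-yl for 1H-benzimidazol-2-yl: the result a number 6 percentage points lower from compound 2 to compound 3 (within the scatter) suggests that trading one such group for another need not move the number much. The two larger steps of a number 14 percentage points lower from compound 1 to compound 2 (beyond the scatter) and a number 20 percentage points lower from compound 1 to compound 3 (beyond the scatter) both leave 1,2,3,4-tetrahydroisoquinolin-3-yl behind, a group that neither compound 3 nor compound 4 carries. Among the measured compounds shown here, no measured compound holds 1,3-benzothiazol-2-yl, so this guidance is indirect. No step beyond the scatter is expected in this assay here. The estimated step is a number 3 percentage points lower from compound 3 to compound 4 (within the scatter) for this exchange. Compound 4 is expected at 65% with a likely range from 48% to 80% remaining.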

Compound 4, percent of the compound remaining: 45%
The estimate for compound 4 lay 20 percentage points above the measured number; the whole stated range lies above it.
By their numbers in this assay, from the lowest: compound 4; then compounds 3 and 2 (each within the scatter of the next); then compound 1.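

In this assay this position proved sensitive to a swap that looks small on paper: the step is a number 23 percentage points lower from compound 3 to compound 4 (beyond the scatter), even though 1H-benzimidazol-2-yl and 1,3-benzothiazol-2-yl have the same number of heavy atoms and the same pair of aromatic rings. What the counts do show is that a nitrogen gives way to a sulfur and the hydrogen-bond donor is gone. The earlier exchange of isoquinolin-3-yl for 1H-benzimidazol-2-yl stayed within the scatter, so a quiet result for aromatic exchanges here does not carry over: the step of a number 29 percentage points lower from compound 2 to compound 4 (beyond the scatter) is clear, and a number 43 percentage points lower from compound 1 to compound 4 (beyond the scatter) is the largest step among these four compounds.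

Nothing available here explains why the number fell with this exchange.

The compounds shown do not separate the loss of the donor from the arrival of sulfur, and 1-methyl-1H-benzimidazol-2-yl, with no donor and no sulfur, or 1,3-benzoxazol-2-yl, with oxygen in the ring, on the same saturated chain carbon would pull those two apart. From the compounds shown here alone, whether the same exchange gives a similar step on a different core also stays open.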